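Cytotoxicity notes on three measured analogues and one untested

The source may hold more compounds than are shown below. What is called first, only, known or untested is meant among the compounds shown, and "the series" means these compounds.

Measured so far:
compound 1 `CCC1(c2cccc(Cl)c2)ON=C(c2ccccc2Cl)O1` – > 100000 nM in an ADME assay on HEK293 cells (Homo sapiens) for cytotoxicity, read by MTT assay, with a stated time of 44 h; on this read-out higher numbers stand for weaker inhibition and lower numbers for stronger inhibition
compound 2 `CCC1(c2cccc(Br)c2)ON=C(c2ccccc2Cl)O1` – > 100000 nM in this assay
compound 3 `Clc1cccc(C2ON=C(c3ccccc3Cl)O2)c1` – > 100000 nM in this assay

Compound 1 stands only at a limit in this assay; its value > 100000 nM is a limit of the assay and not a number. For compound 2 the value > 100000 nM is likewise a limit. For compound 3 the value > 100000 nM is a limit as well. The step from compound 1 to compound 2 reads a step that the two limits leave unreadable from compound 1 to compound 2, and the step from compound 1 to compound 3 reads a step that the two limits leave unreadable from compound 1 to compound 3; both rest on (the limit of > 100000 nM in this assay, at which 3 of the 3 values shown sit).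

Compound 4 `CCC1(c2cccc(Cl)c2)ON=C(c2ccc(Cl)cc2)O1` differs from compound 1 by 4-chlorophenyl in place of 2-chlorophenyl on a carbon with a double bond to nitrogen. Neither measured step touches this change, and neither is readable in size, so no shift beyond the scatter is expected in this assay. Compound 4 is therefore expected at 150000 nM, with a range from 50000 nM to 500000 nM. The estimated step amounts to a step that the limit leaves unreadable from compound 1 to compound 4, most likely ending again at the assay limit.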

Compound 4, half-maximal inhibitory concentration: > 100000 nM
Compound 4 ended at the assay's limit; the forecaster's own chance of this, stated with the estimate: 85%; the middle value is on the limit's open side.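

No new step can be read: compound 1 and compound 4 both stand at a limit and not at a number in this assay, so their difference has no readable size: the limit of > 100000 nM in this assay, at which 4 of the 4 values shown sit.

The compounds shown leave open whether 4-chlorophenyl in place of 2-chlorophenyl changes cytotoxicity at all, and at what concentration any of these analogues would inhibit in this assay.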